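Replacing a Piperazine Ring with a Diethylamino Chain

The source may report more compounds than this note shows. Statements on the series, on what has been measured and on what is new or still open speak of the compounds shown alone.

Three amides built on a shared core have been tested in a functional assay on MCF7 cells (Homo sapiens) for antiproliferative activity, read by MTT assay, with a stated time of 72 h; a higher number here means a weaker inhibitor, a lower number a stronger inhibitor. Compound 1 `Cc1cc(N2CCN(C(C)C)CC2)nc2ccc(NC(=O)c3ccc(Cl)c(Cl)c3)cc12` gives 1710 nM, compound 2 `CCN1CCN(c2cc(C)c3cc(NC(=O)c4ccc(Cl)c(Cl)c4)ccc3n2)CC1` gives 1380 nM, and compound 3 `Cc1cc(N2CCN(C)CC2)nc2ccc(NC(=O)c3ccc(Cl)c(Cl)c3)cc12` gives 3000 nM. Compound 3 thus has the highest of the three numbers: the step of a 1.8-fold higher number from compound 1 to compound 3 (0.24 log units; within the scatter) stays within the scatter, while the step of a 2.2-fold higher number from compound 2 to compound 3 (0.34 log units; beyond the scatter) is a modest one beyond it. The step of a 1.2-fold lower number from compound 1 to compound 2 (0.09 log units; within the scatter) is small as well.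

Compound 4 `CCN(CC)c1cc(C)c2cc(NC(=O)c3ccc(Cl)c(Cl)c3)ccc2n1` has not yet been measured. It differs from compound 3 by diethylamino in place of 4-methylpiperazin-1-yl on an aromatic carbon. Within the data shown here, all three measured steps concern only the group carried on the amine nitrogen of the six-membered non-aromatic ring, and none of them removes that ring, so no measured step bears directly on the present change. What they show is that alterations at this part of the core moved the numbers only slightly in either direction.

On that basis compound 4 is expected to give about 3000 nM, in a range from 1100 nM to 8000 nM. This estimate corresponds to the step of no change at the digits printed from compound 3 to compound 4 (within the scatter), which is expected to lie within the scatter, with no clear direction.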

Compound 4, half-maximal inhibitory concentration: > 50000 nM
Compound 4 was reported as a limit; the forecaster's own chance of this, stated with the estimate: 10%; at least 16-fold (1.22 log units) between middle value and limit.
By their numbers in this assay, from the lowest: compounds 2, 1 and 3 (each within the scatter of the next, the first and the last beyond it). At a limit, above all of these: compound 4.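

Compound 4 is reported only as a limit, not as a number: the limit of > 50000 nM in this assay, at which 1 of the 4 values shown sits. In this assay, the steps among the three piperazines were small or modest, whereas exchanging the ring for the open diethylamino chain gives an at least 16-fold higher number from compound 3 to compound 4 (1.22 log units; beyond the scatter), and the same exchange gives an at least 36-fold higher number from compound 2 to compound 4 (1.55 log units; beyond the scatter) and an at least 29-fold higher number from compound 1 to compound 4 (1.46 log units; beyond the scatter). This position, on an aromatic carbon next to the ring nitrogen, therefore accepts all three piperazines with their different groups on the ring amine nitrogen, while the one compound shown without that six-membered non-aromatic ring stands apart from them, a contrast that the earlier compounds, all of which keep the ring, could not reveal.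

The compounds shown leave open whether the difference follows the loss of the ring or the loss of its second nitrogen, as compound 4 lacks both at once. A piperidine ring, a morpholine ring, or an open chain ending in a second amine at this carbon would be needed to separate the two.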